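This account rests on a few compounds, and the source may have more. Where it says the series, first, only, none or still open, it means among the compounds named here.

Measured compounds:
- compound 1, `COc1ccc(C(=O)Nc2ccccc2F)cc1OC1CCCC1`, gives 10700 nM in an assay on isolated protein for inhibition of phosphodiesterase 4A (Sus scrofa); a lower number here means a stronger inhibitor, a higher number a weaker inhibitor
- compound 2, `COc1ccc(C(=O)Nc2c(F)cccc2F)cc1`, gives 37000 nM in this assay
- compound 3, `COc1ccc(C(=O)Nc2ccccc2Cl)cc1OC(=O)c1ccccc1`, gives > 1000000 nM in this assay

Of the two plain numbers shown, compound 1 gives the lower one; compound 2 gives a higher number, and the gap between the two lies beyond the usual scatter of repeated measurements. For compound 3 the assay reports only a limit and not a number: the limit of > 1000000 nM in this assay, at which 1 of the 3 values shown sits.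

The unmeasured compound 4, `COc1ccc(C(=O)Nc2c(C)nsc2Br)cc1OC1CCCC1`, differs from compound 1 in a single place: 5-bromo-3-methyl-1,2-thiazol-4-yl in place of 2-fluorophenyl on an amide-type nitrogen. Going by the values given here, no pair of measured compounds shows a change of this kind, so there is no measured step to lean on, and the expectation rests only on the size of the change and the values of compound 1 and compound 2. The step from compound 1 to compound 4 is expected to be a 3.6-fold lower number from compound 1 to compound 4 (0.55 log units; beyond the scatter), a modest move towards a stronger inhibitor, with wide uncertainty in both directions. Compound 4 is therefore estimated at 3000 nM, with a likely range from 500 nM to 30000 nM.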

Compound 4, half-maximal inhibitory concentration: 500 nM
The estimate for compound 4 lay 6.0-fold (0.78 log units) above the measured number; low and high end bracket the measured number.
By their numbers in this assay, from the lowest: compound 4; then compound 1; then compound 2. At a limit, above all of these: compound 3.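

With the rest of the molecule held fixed, placing 5-bromo-3-methyl-1,2-thiazol-4-yl in place of 2-fluorophenyl on the amide-type nitrogen gives in this assay a 21-fold lower number from compound 1 to compound 4 (1.33 log units; beyond the scatter). The earlier compounds shown here all carry a six-membered aromatic ring of carbon only at this place, so they could not show that a five-membered aromatic ring with hetero atoms is accepted here, let alone that it can give a much stronger inhibitor. The change replaces the whole ring at once, and no measurement shown explains the gain.

The compounds shown do not separate the contribution of the bromine from that of the methyl or the ring itself. From the compounds shown here alone, it remains open how the number would move with a chlorine in place of the bromine, with a hydrogen there instead, or with a pyridine ring at this place.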